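Swapping the ring on the sulfonyl sulfur: compound 3 to compound 4

A few compounds are considered here, and "the series" means these few. Any claim that something is new, unique, unknown or untested is made for them only; others in the source may bear on it.

Compounds measured in a functional assay on HCT-116 cells (Homo sapiens) for cytotoxicity, read by MTT assay, with a stated time of 72 h; on this read-out higher numbers stand for weaker inhibition and lower numbers for stronger inhibition:
Compound 1, `COc1ncc(-c2ccc3nc(NC(=O)N(C)C)nn3c2)cc1NS(=O)(=O)c1ccc(F)cc1`: 760 nM
Compound 2, `COc1ncc(-c2ccc3nc(NC(=O)NCC(=O)N4CCCC4)nn3c2)cc1NS(=O)(=O)c1ccc(F)cc1`: 140 nM
Compound 3, `CCN(CC)CCNC(=O)Nc1nc2ccc(-c3cnc(OC)c(NS(=O)(=O)c4ccc(C)cc4)c3)cn2n1`: 170 nM

Compound 3 holds the second highest of these three numbers. Its nearest neighbour is compound 2, whose number is lower by an amount within the usual scatter, so the two cannot be ranked against each other. Compound 1 gives a clearly higher number, beyond the scatter. For the measured compounds named here, the only measured step between compounds differing in one place, a 5.4-fold lower number from compound 1 to compound 2 (0.73 log units; beyond the scatter), changes the group on the urea carbonyl carbon and says nothing about the ring on the sulfonyl sulfur.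

Compound 4, `CCN(CC)CCNC(=O)Nc1nc2ccc(-c3cnc(OC)c(NS(=O)(=O)c4ccc(F)cc4F)c3)cn2n1`, differs from compound 3 in one place: 2,4-difluorophenyl in place of 4-methylphenyl on a sulfonyl sulfur. Going by the values given here, no measured pair differs only at this ring, so no step bears directly on the change. Compound 2, which carries a different ring on its sulfonyl sulfur and also a different urea substituent, sits within the scatter of compound 3; that is all the data show about this part of the molecule. With no evidence for a shift in either direction, the step of no change at the digits printed from compound 3 to compound 4 (within the scatter) is expected to stay within the scatter. Compound 4 is therefore estimated at 170 nM, with a range from 70 nM to 400 nM.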

Compound 4, half-maximal inhibitory concentration: 140 nM
Compound 4: middle estimate off by 1.2-fold (0.08 log units), on the high side; measured number inside the range.
By their numbers in this assay, from the lowest: compounds 2, 4 and 3 (each within the scatter of the next); then compound 1.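

In this assay, for the compounds shown here, the swap of 4-methylphenyl for 2,4-difluorophenyl on the sulfonyl sulfur gives a 1.2-fold lower number from compound 3 to compound 4 (0.08 log units; within the scatter), the first reading in which this ring is the only thing that differs. The earlier compounds shown here could not isolate this position, whereas here the rest of the molecule is held fixed and the two numbers cannot be told apart, even though the ring's methyl group gives way to two fluorine atoms and the group goes from 7 heavy atoms to 8. No measurement is available that could explain this result or say what either ring contributes.

As far as these compounds go, both rings in this pair are substituted phenyl rings, so it remains open whether the number would hold with a pyridine ring, a cyclopropyl group or a plain methyl group on the sulfonyl sulfur. This single pair also leaves open whether the same ring swap would read the same way when paired with the urea group of compound 1 or compound 2.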